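Sulfur substituent variation in a growth-inhibition series

The compounds below may be only part of what the source reports. "The series", "measured", "known", "first", "only" and "open" are said of these compounds alone.

Measured so far:
compound 1, `Cc1ccc(SCc2ccc(/C=C/C(=O)Nc3ccccc3N)cc2)cc1`: 6.23%
compound 2, `Cc1cc(C)cc(SCc2ccc(/C=C/C(=O)Nc3ccccc3N)cc2)c1`: 7.98%

In a functional assay on HCT-116 cells (Homo sapiens) for inhibition, read by CCK-8 assay, with a stated time of 72 h, tested at 2 uM (on this read-out higher numbers stand for more inhibition of growth at the one concentration tested and lower numbers for less inhibition of growth), compound 1 gives 6.23% and compound 2 gives 7.98%. Among the compounds with values here, the one measured step, a number 1.8 percentage points higher from compound 1 to compound 2 (within the scatter), is the exchange of 3,5-dimethylphenyl for 4-methylphenyl on the sulfur. Compound 2 thus stands within the scatter of compound 1; the two numbers cannot be told apart, and both sit low at the single concentration tested.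

Compound 3, `Nc1ccccc1NC(=O)/C=C/c1ccc(CSCCc2ccccc2)cc1`, is the next member. Its difference from compound 2 is phenethyl in place of 3,5-dimethylphenyl on a sulfur. Within the data shown here, only the step from compound 1 to compound 2 bears on this, and only loosely: that step swapped one aromatic group for another on the sulfur and stayed within the scatter, whereas here an aromatic group on the sulfur gives way to a two-carbon chain carrying the aromatic ring. Among the measured compounds shown here, no measured step covers such a change, so the expectation rests on the low level of both measured compounds and on the small size of the one known step. The step of a number 0 percentage points higher from compound 2 to compound 3 (within the scatter) is expected to stay within the scatter, with no direction favoured. Compound 3 is estimated at 8%, in the range 0% to 25%.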

Compound 3, percent growth inhibition at one concentration: 18%
Compound 3: the middle estimate sits 10 percentage points below what was measured; low and high end bracket the measured number.
By their numbers in this assay, from the lowest: compounds 1, 2 and 3 (each within the scatter of the next, the first and the last beyond it).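

In this assay, within the data shown here, phenethyl on the sulfur gives the first step at this position that clears the scatter: a number 11.8 percentage points higher from compound 1 to compound 3 (beyond the scatter). Against the other aromatic group the same exchange gives a number 10 percentage points higher from compound 2 to compound 3 (within the scatter), so compound 3 separates from only one of the two compounds with an aromatic ring directly on the sulfur, and the result is a modest hint rather than a clear divide between the two kinds of substituent. Since phenethyl and 3,5-dimethylphenyl have the same heavy-atom count and one aromatic ring each, the comparison of compound 2 with compound 3 concerns how those atoms are joined rather than how many there are, and nothing available explains the numbers at this position.

From the compounds shown here alone, it remains open whether the trend seen with phenethyl continues with a benzyl group, a longer chain between the sulfur and the phenyl ring, or a chain ending in an amine. It is also open whether the order of these compounds would hold at other concentrations, as every number here comes from a single tested concentration.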